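Replacing the benzyl substituent on the core with a carboxy chain

The source may report more compounds than this note shows. Statements on the series, on what has been measured and on what is new or still open speak of the compounds shown alone.

The series shares the core of compound 1 `O=c1c2ccccc2c(-c2cccnc2)nn1Cc1ccccc1`. In a functional assay (trachea) with Cavia porcellus as the target (a lower number here means a stronger inhibitor, a higher number a weaker inhibitor), compound 1 gives 2450 nM, the lowest number among the three measured compounds. Compound 2 `COC(=O)c1ccc(Cn2nc(-c3cccnc3)c3ccccc3c2=O)cc1` gives 5890 nM; compound 3 `O=c1c2ccccc2c(-c2cccnc2)nn1S(=O)(=O)c1ccccc1` gives 14800 nM. Going by the values given here, the one step with a single change is a 2.4-fold higher number from compound 1 to compound 2 (0.38 log units; beyond the scatter). Among the compounds with values here, for compound 3 no single-change step is defined; its value is simply the highest of the three.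

Compound 4 `O=C(O)CCCn1nc(-c2cccnc2)c2ccccc2c1=O` differs from compound 1 as follows: 2-carboxyethyl in place of phenyl on a saturated chain carbon bound to an aromatic nitrogen. Cut one bond further out, this reads as benzyl to 3-carboxypropyl.

What bears on this step: the step from compound 1 to compound 2 shows that adding methoxycarbonyl to the phenyl already costs a modest amount; compound 3 shows that a larger alteration at the aromatic nitrogen can cost more. The change to compound 4 removes the phenyl altogether and puts in a chain carrying a hydrogen-bond donor and acceptor, which is not sampled by any measured pair, so the direction is uncertain and the step is expected to be modest, most likely toward a higher number. The estimated step is a 2.4-fold higher number from compound 1 to compound 4 (0.39 log units; beyond the scatter). Compound 4 is therefore expected to give 6000 nM, within 2000 nM to 20000 nM.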

Compound 4, half-maximal inhibitory concentration: > 100000 nM
Compound 4 was reported as a limit; the forecaster's own chance of this, stated with the estimate: 10%; middle value at least 16-fold (1.22 log units) away from the limit.
By their numbers in this assay, from the lowest: compound 1; then compound 2; then compound 3. At a limit, above all of these: compound 4.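

Compound 4 is reported only as a limit in this assay, not as a number: the limit of > 100000 nM in this assay, at which 1 of the 4 values shown sits.

Even read as a limit, the change is large, with an at least 40-fold higher number from compound 1 to compound 4 (1.61 log units; beyond the scatter). This far exceeds the modest cost of adding methoxycarbonyl to the phenyl, a 2.4-fold higher number from compound 1 to compound 2 (0.38 log units; beyond the scatter), so compound 2 keeps much of the value of compound 1 while compound 4 does not. Going by these compounds alone, on a saturated chain carbon bound to an aromatic nitrogen, the exchange of phenyl for 2-carboxyethyl therefore matters far more than the one change to the phenyl seen so far, and the benzyl to 3-carboxypropyl swap is the first change to reach the assay limit.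

This single step removes the phenyl and brings in the carboxylic acid together, so the compounds shown cannot say which of the two accounts for the loss. The methyl ester of the same chain, a plain propyl chain, or a carboxylic acid carried on the phenyl of the benzyl group would pull the two apart.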